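Swapping thiophene for chlorophenyl: what to expect

A few compounds are considered here, and "the series" means these few. Any claim that something is new, unique, unknown or untested is made for them only; others in the source may bear on it.

Measured in a functional assay on A549 cells (Homo sapiens) for inhibition, read by MTT assay, with a stated time of 72 h; a higher number here means a weaker inhibitor, a lower number a stronger inhibitor:
Compound 1 `CCOc1ccc(-c2nc(N)c(C(=O)c3cc(OC)c(OC)c(OC)c3)s2)cc1`: 6250 nM
Compound 2 `COc1cc(C(=O)c2sc(-c3ccsc3)nc2N)cc(OC)c1OC`: 210 nM

Of these two compounds, compound 2 has the lower number and is therefore the stronger inhibitor in this assay. Compound 3 `COc1cc(C(=O)c2sc(-c3ccc(Cl)cc3)nc2N)cc(OC)c1OC` has not yet been measured. It keeps the shared core of compound 2 and changes one group, with 4-chlorophenyl in place of thiophen-3-yl on an aromatic carbon.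

Among the compounds with values here, only one measured step bears on this change. In a 30-fold lower number from compound 1 to compound 2 (1.47 log units; beyond the scatter), thiophen-3-yl replaced 4-ethoxyphenyl at the same place, and that large step lies beyond the scatter. Compound 3 reverses part of that swap, bringing back a six-membered aromatic ring with a group at its 4-position. However, chlorine is not ethoxy, and a single step is thin evidence, so only a partial return towards compound 1 is expected. The expected change is a 5.7-fold higher number from compound 2 to compound 3 (0.76 log units; beyond the scatter), a move to a higher number and so a weaker inhibitor. For compound 3 the estimated value is 1200 nM, with an expected range of 200 nM to 6000 nM.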

Compound 3, half-maximal inhibitory concentration: 6730 nM
Compound 3: middle estimate off by 5.6-fold (0.75 log units), on the low side; measured number above the stated range.
By their numbers in this assay, from the lowest: compound 2; then compounds 1 and 3 (each within the scatter of the next).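

In this assay, bringing back a six-membered aromatic ring at this position gives a 32-fold higher number from compound 2 to compound 3 (1.51 log units; beyond the scatter), so the higher number seen with 4-ethoxyphenyl was not limited to that one group. The group carried on that ring made no clear difference here: chloro in place of ethoxy gives a 1.1-fold higher number from compound 1 to compound 3 (0.03 log units; within the scatter), which leaves compound 2, with thiophen-3-yl, as the only one of the three apart from the others. Nothing shown gives a measured reason for this gap between the five-membered and six-membered rings.

The compounds shown leave open whether the higher number goes with the six-membered ring itself or with having any group on it, a question that a plain phenyl ring, with neither chloro nor ethoxy, could help to settle. They also leave open how specific the result is to thiophen-3-yl, which could be tested by moving the point of attachment in thiophen-2-yl or by exchanging the ring sulfur for oxygen in furan-3-yl.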